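Shifting the Methyl on the Phenoxy Group

A few compounds are considered here, and "the series" means these few. Any claim that something is new, unique, unknown or untested is made for them only; others in the source may bear on it.

Compound 1 `O=C(COc1ccc(Cl)cc1)Nc1nc(-c2ccc(Br)cc2)cs1` and compound 2 `Cc1ccccc1OCC(=O)Nc1nc(-c2ccc(Br)cc2)cs1` share the same core and differ only in the aromatic ring attached to the ether oxygen. In a functional assay on MCF7 cells (Homo sapiens) for cytotoxicity, read by MTT assay, with a stated time of 48 h (on this read-out higher numbers stand for weaker inhibition and lower numbers for stronger inhibition), compound 1 gives 41100 nM, and in this assay compound 2 gives 40100 nM. Among the compounds with values here, compound 2 holds the lowest of the two numbers so far, but its only neighbour is compound 1, and the step of a 1.0-fold lower number from compound 1 to compound 2 (0.01 log units; within the scatter) shows that the two cannot be told apart. Compound 3 `Cc1ccc(OCC(=O)Nc2nc(-c3ccc(Br)cc3)cs2)cc1` is the next member, carrying the change (4-methylphenyl in place of 2-methylphenyl on an oxygen on a saturated carbon). Within the data shown here, the one measured step, from compound 1 to compound 2, also swapped groups on the same oxygen and produced no shift beyond the scatter, so a similarly flat outcome is expected here, with the step of a 1.0-fold lower number from compound 2 to compound 3 (0.00 log units; within the scatter) for compound 3 lying within the usual spread. In this assay compound 3 is therefore estimated at 40000 nM, between 20000 nM and 80000 nM.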

Compound 3, half-maximal inhibitory concentration: 52200 nM
Compound 3: middle estimate off by 1.3-fold (0.12 log units), on the low side; the measured number falls inside the stated range.
By their numbers in this assay, from the lowest: compounds 2, 1 and 3 (each within the scatter of the next).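

Moving the methyl group, which turns 2-methylphenyl into 4-methylphenyl with the same atoms joined differently, gives a 1.3-fold higher number from compound 2 to compound 3 (0.11 log units; within the scatter) in this assay, so the two placements of the methyl cannot be told apart here. Compound 3 also allows a new one-place comparison, methyl in place of chloro on an aromatic carbon, and this gives a 1.3-fold higher number from compound 1 to compound 3 (0.10 log units; within the scatter), so that swap cannot be read as a real change either. Nothing available offers an explanation for these results.

As far as these compounds go, all three compounds carry a substituted phenyl on the oxygen, so it remains open whether an amine or a carboxylic acid on that ring would move the number beyond the scatter. From the compounds shown here alone, it also remains open whether a longer chain carrying the oxygen, or a change elsewhere on the shared core, would do so.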